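A few compounds are considered here, and "the series" means these few. Any claim that something is new, unique, unknown or untested is made for them only; others in the source may bear on it.

Compound 1 `COc1ccc(-c2[nH]c3ccccc3c2/C=C(\C#N)S(=O)(=O)c2ccccc2)cc1` gives 528 nM in a functional assay on SK-OV-3 cells (Homo sapiens) for inhibition, read by sulforhodamine B assay, with a stated time of 48 h; a higher number here means a weaker inhibitor of growth, a lower number a stronger inhibitor of growth. Compound 2 `O=C(/C(=C\c1c(-c2ccccc2)[nH]c2ccccc12)S(=O)(=O)c1ccccc1)c1ccccc1` gives 7600 nM in this assay.

Of the two measured compounds, compound 2 has the highest number, and its gap to compound 1 lies beyond the scatter. Compound 3 `N#C/C(=C\c1c(-c2ccccc2)[nH]c2ccccc12)S(=O)(=O)c1ccccc1` differs from compound 2 by cyano in place of benzoyl on a double-bonded chain carbon bound to a double-bonded chain carbon and a sulfonyl sulfur. Within the data shown here, no measured pair shows this step on its own; compound 1, which also carries a cyano at that position, gives 528 nM, so a move toward lower numbers is expected. Compound 3 is expected at 1000 nM, within 300 nM to 3500 nM, a step of a 7.6-fold lower number from compound 2 to compound 3 (0.88 log units; beyond the scatter).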

Compound 3, concentration for 50% growth inhibition: 6800 nM
Compound 3: middle estimate off by 6.8-fold (0.83 log units), on the low side; measured number above the stated range.
By their numbers in this assay, from the lowest: compound 1; then compounds 3 and 2 (each within the scatter of the next).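

In this assay, cyano in place of benzoyl on a double-bonded chain carbon bound to a double-bonded chain carbon and a sulfonyl sulfur changes almost nothing (a 1.1-fold lower number from compound 2 to compound 3 (0.05 log units; within the scatter)). Hydrogen in place of methoxy on an aromatic carbon, by contrast, gives a large step (a 13-fold higher number from compound 1 to compound 3 (1.11 log units; beyond the scatter)), so among these compounds the difference in growth inhibition follows the methoxy and not the cyano. Nothing available explains either step.

As far as these compounds go, it remains open whether benzoyl and cyano would also match when methoxy is present. From the compounds shown here alone, whether an amine or a hydroxyl on that aromatic carbon would act like methoxy also remains open.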